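A few compounds are considered here, and "the series" means these few. Any claim that something is new, unique, unknown or untested is made for them only; others in the source may bear on it.

In an assay on CHO cells for displacement of a labelled ligand from D(4) dopamine receptor (Homo sapiens), read by radioligand binding (a lower number here means a stronger inhibitor, a higher number a weaker inhibitor), three compounds have been measured:

compound 1, `COc1ccccc1N1CCN(CCCNC(=O)NN(Cc2ccccc2)c2ccc(Cl)cc2)CC1`, gives 2.9 nM
compound 2, `COc1ccccc1N1CCN(CCCNC(=O)NN(Cc2ccccc2F)c2ccc(Cl)cc2)CC1`, gives 2.6 nM
compound 3, `O=C(NCCCN1CCN(c2ccc(Cl)cc2)CC1)NN(Cc1ccccc1)c1ccccc1`, gives 9.7 nM

Compound 1 and compound 2 share one core and differ by fluoro in place of hydrogen on an aromatic carbon. That step gives a 1.1-fold lower number from compound 1 to compound 2 (0.05 log units; within the scatter). Compound 3 is built on another core; the difference between the core of compound 3 and the core of compound 1 is not broken down here. In this assay compound 3 gives the highest of the three numbers, and its distance from compound 1 as well as from compound 2 lies beyond the scatter.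

Compound 4, `O=C(NCCCN1CCN(c2ccc(Cl)cc2)CC1)NN(Cc1ccc(F)cc1)c1ccccc1`, carries the core of compound 3 with fluoro in place of hydrogen on an aromatic carbon. For the measured compounds named here, this is the same kind of change as the one from compound 1 to compound 2, not the same: there the fluoro sits ortho to a large group, here para to a large group. The step is expected to be a 1.2-fold lower number from compound 3 to compound 4 (0.08 log units; within the scatter), because a 1.1-fold lower number from compound 1 to compound 2 (0.05 log units; within the scatter) stayed within the scatter. Compound 4 is therefore estimated to give 8 nM in this assay, between 3.5 nM and 18 nM.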

Compound 4, inhibition constant: 17 nM
Beside the measured number, compound 4's estimate is 2.1-fold (0.33 log units) below it; low and high end bracket the measured number.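

In this assay fluoro in place of hydrogen gives a 1.8-fold higher number from compound 3 to compound 4 (0.24 log units; within the scatter) and so leaves the number within the scatter on this core, as it did on the core of compound 1. Set side by side, the two steps cannot be told apart: the same change on two cores in this assay, a 1.1-fold lower number (0.05 log units; within the scatter) from compound 1 to compound 2 and a 1.8-fold higher number (0.24 log units; within the scatter) from compound 3 to compound 4, 2.0-fold (0.29 log units) apart, within the scatter of two such steps. For the compounds shown here, this shows that, across these two pairs, the change carried from one core to the other without a step that can be read, but it does not show that fluoro is without consequence throughout the series, since only two pairs are available and the fluoro does not sit in the same place in both.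

From the compounds shown here alone, it remains open whether fluoro placed as in compound 2 would give a similar step on the core of compound 3, and whether 4-fluorobenzyl would do so on the core of compound 1. Also open, going by these compounds, is whether a larger group on the benzyl, such as trifluoromethyl or bromo, or a longer chain in the linker, would move the number beyond the scatter.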